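The compounds below may be only part of what the source reports. "The series", "measured", "known", "first", "only" and "open" are said of these compounds alone.

Of the compounds shown here, three with a shared core have been measured. Compound 1 `COc1ccc2[nH]c(-c3nc(C)no3)cc2c1`, compound 2 `Cc1noc(-c2cc3cc(Cl)ccc3[nH]2)n1` and compound 3 `Clc1ccc(-c2noc(-c3cc4ccccc4[nH]3)n2)cc1` were each tested in a functional assay on COLO 320 cells (Homo sapiens) for antiproliferative activity, read by WST assay, with a stated time of 72 h; a higher number here means a weaker inhibitor, a lower number a stronger inhibitor. In this assay compound 1 gives 10400 nM, compound 2 gives 19500 nM and compound 3 gives 13900 nM; all three numbers lie within the usual scatter of one another, so no ordering among them can be claimed.

Compound 2 and compound 1 differ in one place, (methoxy in place of chloro on an aromatic carbon). That change gave the step of a 1.9-fold lower number from compound 2 to compound 1 (0.27 log units; within the scatter). How the core of compound 3 differs from the core of compound 2 is not broken down here.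

Compound 4 `COc1ccc(-c2noc(-c3cc4ccccc4[nH]3)n2)cc1` is not yet measured. It differs from compound 3 by methoxy in place of chloro on an aromatic carbon. Going by the values given here, this is the same kind of change as the one from compound 2 to compound 1, but not the same: there the group sat on a ring that is part of a fused or bridged system of two rings, meta to a fused ring and para to a fused ring, whereas here it sits on a six-membered aromatic ring of carbon only, para to a large group.

Resting on the step of a 1.9-fold lower number from compound 2 to compound 1 (0.27 log units; within the scatter), the step expected for compound 4 is a 1.5-fold lower number from compound 3 to compound 4 (0.19 log units; within the scatter). In this assay compound 4 is therefore estimated at 9000 nM, with a likely range from 4000 nM to 25000 nM.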

Compound 4, half-maximal inhibitory concentration: 27700 nM
Beside the measured number, compound 4's estimate is 3.1-fold (0.49 log units) below it; measured number above the stated range.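

In this assay, putting methoxy in place of chloro on the six-membered aromatic ring of carbon only gave a 2.0-fold higher number from compound 3 to compound 4 (0.30 log units; within the scatter), and set beside the earlier case, the same change did not behave alike on the two cores: the same change on two cores in this assay, a 1.9-fold lower number (0.27 log units; within the scatter) from compound 2 to compound 1 and a 2.0-fold higher number (0.30 log units; within the scatter) from compound 3 to compound 4, 3.7-fold (0.57 log units) apart, beyond the scatter of two such steps

Each step taken alone lies within the scatter, and only the gap between them lies beyond it, so the step seen on one core cannot be carried to the other as a fixed amount. This does not show why the two steps part, nor what the change would do on a further core, since the comparison rests on two pairs of compounds only, with the group sitting in a different place in each pair.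

The compounds shown leave open what an amine, a carboxylic acid or a longer chain such as ethoxy would give at the position para to a large group on that ring. They also leave open whether methoxy in place of chloro would follow compound 1 or compound 4 on a third core, which would need another matched pair.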